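The source may report more compounds than this note shows. Statements on the series, on what has been measured and on what is new or still open speak of the compounds shown alone.

Compound 1 `CCc1nc(-c2ccc(OCCC(C)CCN3CCN(c4ccncc4)C3=O)cc2)no1` was tested in an ADME assay on cells (Homo sapiens) for cytotoxicity; on this read-out higher numbers stand for lower toxicity in this test and lower numbers for higher toxicity in this test. In this assay compound 1 gives > 25000 nM, which is a limit of the test and not a number. For the measured compounds named here, compound 2 `Cc1cc(COc2ccc(-c3ccc(Cl)cc3)cc2)cc(CN2CCN(c3ccncc3)C2=O)c1` is the only other measured compound. In this assay compound 2 gives > 25000 nM, again a limit rather than a number. The common picture is the limit of > 25000 nM in this assay, at which 2 of the 2 values shown sit, so compound 1 stands at that limit with no number of its own to place it. Going by the values given here, no pair of measured compounds differs in one place, so no measured step is at hand. Compound 3 `CCn1nnc(-c2ccc(OCCC(C)CCN3CCN(c4ccncc4)C3=O)cc2)n1` has not yet been measured. It differs from compound 1 by 2-ethyl-2H-tetrazol-5-yl in place of 5-ethyl-1,2,4-oxadiazol-3-yl on an aromatic carbon. With both known values sitting at the limit, no step beyond the scatter is expected, and the expected step that the limit leaves unreadable from compound 1 to compound 3 lies within it. Compound 3 is therefore estimated at 30000 nM, in a range from 15000 nM to 60000 nM, most likely reported once more as a limit.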

Compound 3, half-maximal cytotoxic concentration: > 12500 nM
Compound 3 ended at the assay's limit; the forecaster's own chance of this, stated with the estimate: 85%; the middle value is on the limit's open side.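

In this assay, for the compounds shown here, compound 1 and compound 3 each stand at a limit of the test and not at a number, and no step between them can be read. The compounds shown leave open whether 2-ethyl-2H-tetrazol-5-yl and 5-ethyl-1,2,4-oxadiazol-3-yl differ at all on this read-out.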